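Series notes: 4-chlorophenyl for naphthalen-2-yl on the sulfonyl sulfur

The source may report more compounds than this note shows. Statements on the series, on what has been measured and on what is new or still open speak of the compounds shown alone.

- Compound 1 `NCCCCN(C[C@@H]1CN(C(=O)c2ccco2)CCN1)[C@H]1CCCc2cccnc21`: > 10 uM (a limit)
- Compound 2 `NCCCCN(C[C@@H]1CN(C(=O)OCc2ccccc2)CCN1)[C@H]1CCCc2cccnc21`: > 10 uM (a limit)
- Compound 3 `NCCCCN(C[C@H]1CN(S(=O)(=O)c2ccc3ccccc3c2)CCN1)[C@H]1CCCc2cccnc21`: > 10 uM (a limit)
- Compound 4 `NCCCCN(C[C@H]1CN(S(=O)(=O)c2ccc(Cl)cc2)CCN1)[C@H]1CCCc2cccnc21`: not yet measured

In an ADME assay on MAGI cells (Homo sapiens) for cytotoxicity (on this read-out lower numbers stand for higher toxicity in this test and higher numbers for lower toxicity in this test), compound 3 gives > 10 uM, which is a limit and not a number. The next change is 4-chlorophenyl in place of naphthalen-2-yl on a sulfonyl sulfur. Among the measured compounds shown here, the only measured step, a step that the two limits leave unreadable from compound 1 to compound 2, lies on a carbonyl carbon and has no readable size. The remaining evidence is the limit of > 10 uM in this assay, at which 3 of the 3 values shown sit. For the measured compounds named here, no measured step therefore bears directly on this change, and no step beyond the scatter, in either direction, is expected in this assay. The expected step is a step that the limit leaves unreadable from compound 3 to compound 4. Compound 4 is estimated at 20 uM, with an expected range of 10 uM to 50 uM.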

Compound 4, half-maximal toxic concentration: > 10 uM
Compound 4 ended at the assay's limit; the forecaster's own chance of this, stated with the estimate: 80%; the middle value lies beyond the limit too.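

No step can be read from compound 3 to compound 4, as both values are limits and not numbers: the limit of > 10 uM in this assay, at which 4 of the 4 values shown sit.

The compounds shown leave open where the actual toxic concentration of any of them lies in this assay, and whether any change on the shared core alters it.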